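Hydrazone variation on the shared core: outlook for compound 4

The source may report more compounds than this note shows. Statements on the series, on what has been measured and on what is new or still open speak of the compounds shown alone.

Measured in a functional assay on A549 cells (Homo sapiens) for antiproliferative activity, read by MTT assay; a lower number here means a stronger inhibitor, a higher number a weaker inhibitor:
- compound 1 `Cn1c(=O)c(=O)n(C2CCCC2)c2nc(N/N=C/c3ccc(Cl)cc3)ncc21` gives 6890 nM
- compound 2 `Cn1c(=O)c(=O)n(C2CCCC2)c2nc(N/N=C/c3ccc(S(C)(=O)=O)cc3)ncc21` gives 84500 nM
- compound 3 `Cn1c(=O)c(=O)n(C2CCCC2)c2nc(N/N=C/c3ccc(O)c(F)c3)ncc21` gives 97800 nM

Compound 1 holds the lowest number of the three. Both exchanges of its chloro-bearing ring for a more polar one cost potency: a 12-fold higher number from compound 1 to compound 2 (1.09 log units; beyond the scatter) and a 14-fold higher number from compound 1 to compound 3 (1.15 log units; beyond the scatter). Between compound 2 and compound 3 the values lie close together.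

Compound 4 `Cn1c(=O)c(=O)n(C2CCCC2)c2nc(N/N=C/c3cccc([N+](=O)[O-])c3)ncc21` differs from compound 1 as follows: 3-nitrophenyl in place of 4-chlorophenyl on a carbon with a double bond to nitrogen. The nitro group, like methylsulfonyl in compound 2, brings acceptors where none stood, so a step of the same kind is expected, a 5.1-fold higher number from compound 1 to compound 4 (0.71 log units; beyond the scatter), though the changed ring position leaves its size uncertain. Compound 4 is estimated at 35000 nM, range 9000 nM to 130000 nM.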

Compound 4, half-maximal inhibitory concentration: 12300 nM
Beside the measured number, compound 4's estimate is 2.8-fold (0.45 log units) above it; low and high end bracket the measured number.
By their numbers in this assay, from the lowest: compounds 1 and 4 (each within the scatter of the next); then compounds 2 and 3 (each within the scatter of the next).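

In this assay, acceptors on this ring do not by themselves cost potency: 3-nitrophenyl, which brings hydrogen-bond acceptors, stays level with 4-chlorophenyl (a 1.8-fold higher number from compound 1 to compound 4 (0.25 log units; within the scatter)). The same group stands clearly apart from the two weaker rings (a 6.9-fold lower number from compound 2 to compound 4 (0.84 log units; beyond the scatter); an 8.0-fold lower number from compound 3 to compound 4 (0.90 log units; beyond the scatter)), so the loss seen with 4-(methylsulfonyl)phenyl and 3-fluoro-4-hydroxyphenyl does not follow every replacement of 4-chlorophenyl. Nothing available accounts for these differences.

Going by these compounds, whether the nitro group itself or its ring position carries this result stays open. Also open, on these data alone, is whether an amine or a carboxylic acid on this ring would stay level with compound 1 or fall towards compound 2 and compound 3.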